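Swapping a methoxy for a nitro in compound 2

The source may report more compounds than this note shows. Statements on the series, on what has been measured and on what is new or still open speak of the compounds shown alone.

- Compound 1 `COc1cc(OC)c2sc(-c3ccc(N/C=C\C(=O)c4cc(OC)c(OC)c(OC)c4)c(C)c3)nc2c1`: 14400 nM
- Compound 2 `COc1cc(OC)c2sc(-c3ccc(N/C=C\C(=O)c4cc(OC)c(OC)c(OC)c4)cc3)nc2c1`: 21800 nM
- Compound 3 `COc1cc(OC)c2sc(-c3ccc(N/C=C\C(=O)c4ccc(OC)c(F)c4)cc3)nc2c1`: 5300 nM

All three were tested in a functional assay on A549 cells (Homo sapiens) for antiproliferative activity, read by sulforhodamine B assay, with a stated time of 48 h; on this read-out higher numbers stand for weaker inhibition and lower numbers for stronger inhibition. With 21800 nM, compound 2 shares the weak end of this small set with its nearest neighbour, as the data show a 1.5-fold higher number from compound 1 to compound 2 (0.18 log units; within the scatter). The other gap is clearer: a 4.1-fold lower number from compound 2 to compound 3 (0.61 log units; beyond the scatter).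

Compound 4 `COc1cc(OC)c2sc(-c3ccc(N/C=C\C(=O)c4cc(OC)c(OC)c([N+](=O)[O-])c4)cc3)nc2c1` is still unmeasured and differs from compound 2 at one place on the 3,4,5-trimethoxyphenyl group. The change is nitro in place of methoxy on an aromatic carbon, ortho to a methoxy group.

Going by the values given here, only one measured change touches this ring, and it is modest but beyond the scatter: a 4.1-fold lower number from compound 2 to compound 3 (0.61 log units; beyond the scatter). That change replaces the whole ring pattern, whereas compound 4 alters a single group, so a smaller step in the same direction seems a fair expectation. The other measured change, a 1.5-fold higher number from compound 1 to compound 2 (0.18 log units; within the scatter), lies elsewhere in the molecule and offers little guidance. Among the compounds with values here, no measured compound carries a nitro, so the direction remains uncertain. The estimated step, a 1.7-fold lower number from compound 2 to compound 4 (0.22 log units; within the scatter), is small and may not clear the scatter. For compound 4 the expected value is 13000 nM, with an estimated range of 4500 nM to 35000 nM.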

Compound 4, half-maximal inhibitory concentration: 13000 nM
Compound 4: middle estimate and measured number agree at the digits printed; the range from low to high includes it.
By their numbers in this assay, from the lowest: compound 3; then compounds 4, 1 and 2 (each within the scatter of the next).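

In this assay, exchanging one methoxy of the 3,4,5-trimethoxyphenyl group for a nitro gives a 1.7-fold lower number from compound 2 to compound 4 (0.22 log units; within the scatter) and so does not clearly shift the number. Until now, the only change shown on this ring replaced its whole substitution pattern, with a 4.1-fold lower number from compound 2 to compound 3 (0.61 log units; beyond the scatter) as the result; this new pair isolates a single place, on an aromatic carbon ortho to a methoxy group, and shows that a nitro there leaves the number within the scatter of the methoxy compound. No measurement in hand speaks to why these two different groups give numbers this close.

As far as these compounds go, what an amine or a carboxylic acid would do at this same place remains open, and one exchange at one place cannot show whether other groups there would shift the number further. The step to compound 3 alters several parts of the ring at once, and the compounds shown do not separate the contribution of the fluoro from that of the methoxy groups that are gone.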